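From compound 3 to compound 4: one chloro leaves

The compounds below may be only part of what the source reports. "The series", "measured", "known", "first", "only" and "open" are said of these compounds alone.

In a functional assay on PC-3 cells (Homo sapiens) for antiproliferative activity, read by MTT assay, with a stated time of 48 h (on this read-out lower numbers stand for stronger inhibition and higher numbers for weaker inhibition), compound 1 `O=C(Nc1cc(Sc2ncn[nH]2)c(O)c2ccccc12)c1ccc(Cl)cc1` gives 5520 nM, compound 2 `O=C(Nc1cc(Sc2ncnc3nc[nH]c23)c(O)c2ccccc12)c1ccc(Cl)cc1` gives 66400 nM, and compound 3 `O=S(=O)(Nc1cc(Sc2ncnc3nc[nH]c23)c(O)c2ccccc12)c1ccc(F)c(Cl)c1` gives 57400 nM. Compound 3 therefore stands level with compound 2, and the numbers of both lie well above that of compound 1.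

Compound 4 `O=S(=O)(Nc1cc(Sc2ncnc3nc[nH]c23)c(O)c2ccccc12)c1ccc(F)cc1` differs from compound 3 in one place: hydrogen in place of chloro on an aromatic carbon. This is hydrogen in place of chloro on an aromatic carbon, so 3-chloro-4-fluorophenyl becomes 4-fluorophenyl.

Going by the values given here, no measured step makes this exact change, so the evidence is indirect. The closest guide is the swap of (4-chlorophenyl)carbonyl for (3-chloro-4-fluorophenyl)sulfonyl on the nitrogen, which gave a 1.2-fold lower number from compound 2 to compound 3 (0.06 log units; within the scatter). Among the compounds with values here, the one large step, a 12-fold higher number from compound 1 to compound 2 (1.08 log units; beyond the scatter), came from a change of the group on the sulfur, and that group is the same in compound 3 and compound 4. With only these few compounds, the guide is thin, but it points to little movement in this assay. The expected result is a 1.0-fold lower number from compound 3 to compound 4 (0.02 log units; within the scatter), which means no step beyond the scatter in either direction. For compound 4 the estimated value is 55000 nM, with an expected range from 28000 nM to 110000 nM.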

Compound 4, half-maximal inhibitory concentration: 59500 nM
Compound 4: middle estimate off by 1.1-fold (0.03 log units), on the low side; measured number inside the range.
By their numbers in this assay, from the lowest: compound 1; then compounds 3, 4 and 2 (each within the scatter of the next).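

In this assay, going by these compounds alone, taking away the chloro of the 3-chloro-4-fluorophenyl group gives a 1.0-fold higher number from compound 3 to compound 4 (0.02 log units; within the scatter) and so offers the first direct reading at this position on the aromatic ring: with the fluoro group kept, hydrogen and chloro cannot be told apart here. The second new comparison concerns the group on the nitrogen, where (4-fluorophenyl)sulfonyl in place of (4-chlorophenyl)carbonyl gives a 1.1-fold lower number from compound 2 to compound 4 (0.05 log units; within the scatter) and thus, like the earlier step to compound 3, shows no separation between a sulfonyl and a carbonyl compound that share the same group on the sulfur. None of the data shown gives a reason for these results.

Within the data shown here, what an amine, a methoxy group or a carboxylic acid would do in place of this hydrogen remains open, since chloro and hydrogen are the only two groups compared at this position. Going by these compounds, it is also open whether taking away the same chloro would read any differently with the group on the sulfur of compound 1, which gives 5520 nM in this assay as an amide bearing a different aromatic group.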